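A few compounds are considered here, and "the series" means these few. Any claim that something is new, unique, unknown or untested is made for them only; others in the source may bear on it.

In a functional assay on the whole organism with Scenedesmus acutus as the target, read by spectrophotometry (a lower number here means a stronger inhibitor, a higher number a weaker inhibitor), compound 1 (`Cc1cc(Cl)ccc1/N=c1\sc(=S)n2n1CCCC2`) gives 275 nM. That is a higher number than compound 2 (`S=c1n(-c2ccc(Cl)cc2)c(=S)n2n1CCCC2`) at 43.7 nM and a lower number than compound 3 (`S=c1n(-c2ccccc2)c(=S)n2n1CCCC2`) at 6310 nM, so compound 1 sits second highest of the three.

Compound 4 (`Fc1cc(Cl)ccc1/N=c1\sc(=S)n2n1CCCC2`) departs from compound 1 by fluoro in place of methyl on an aromatic carbon, ortho to a large group and meta to a chloro group.

Within the data shown here, no measured step covers this swap. The only one available, a 140-fold higher number from compound 2 to compound 3 (2.16 log units; beyond the scatter), is large and beyond the scatter, but it is hydrogen in place of chloro, and it sits on a different core. Compound 4 keeps its chloro group, so a change on the scale of a 140-fold higher number from compound 2 to compound 3 (2.16 log units; beyond the scatter) is not expected. A modest move in this assay is expected instead, tentatively towards a lower number, though the data give no direct support for that direction.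

The estimate amounts to a 2.3-fold lower number from compound 1 to compound 4 (0.36 log units; beyond the scatter), an expected step of modest size. For compound 4 the estimated value is 120 nM, with an expected range from 30 nM to 450 nM.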

Compound 4, half-maximal inhibitory concentration: 67.6 nM
Beside the measured number, compound 4's estimate is 1.8-fold (0.25 log units) above it; low and high end bracket the measured number.
By their numbers in this assay, from the lowest: compounds 2 and 4 (each within the scatter of the next); then compound 1; then compound 3.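

At the aromatic carbon ortho to a large group and meta to a chloro group, in this assay, fluoro in place of methyl gives a 4.1-fold lower number from compound 1 to compound 4 (0.61 log units; beyond the scatter) and so moves the number beyond the scatter. The earlier step of a 140-fold higher number from compound 2 to compound 3 (2.16 log units; beyond the scatter) showed only the replacement of chloro on a different core. This new step shows that a second substituent on the ring also shifts the number while chloro stays in place, here on the core of compound 1, and that this single-atom swap gives a modest step rather than a large one. Nothing measured here accounts for the size or direction of this step.

From the compounds shown here alone, whether hydrogen, methoxy or an amine at this position would give a lower or higher number than fluoro remains open. Also open, going by these compounds, is whether removing chloro from the core of compound 1 would give a step as large as that seen on the other core.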